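A few compounds are considered here, and "the series" means these few. Any claim that something is new, unique, unknown or untested is made for them only; others in the source may bear on it.

In a functional assay on A2780 cells (Homo sapiens) for cytotoxicity (a lower number here means a stronger inhibitor, a higher number a weaker inhibitor), compound 1 `CCc1cnc(CSc2cnc(NC(C)=O)s2)o1` gives 1400 nM, compound 2 `CC(=O)Nc1ncc(SCc2ncc(CC3CCCCC3)o2)s1` gives 1540 nM, and compound 3 `CC(C)(C)C(=O)Nc1ncc(SCc2ncc(C(C)(C)C)o2)s1` gives 250 nM. That last number is the lowest of the three and lies beyond the scatter of both others. Compound 4 `CC(C)OC(=O)Nc1ncc(SCc2ncc(C(C)(C)C)o2)s1` differs from compound 3 in a single change: isopropoxy in place of tert-butyl on a carbonyl carbon. Isopropoxy thus stands in place of tert-butyl on a carbonyl carbon. Within the data shown here, the only measured step, a 1.1-fold higher number from compound 1 to compound 2 (0.04 log units; within the scatter), is a change on a saturated chain carbon bound to an aromatic carbon, not on a carbonyl carbon, so it bears only weakly on this change. Among the measured compounds shown here, no measured pair isolates the carbonyl substituent, so no shift beyond the scatter is expected in either direction, though the uncertainty is wide. The expected step is a 1.2-fold higher number from compound 3 to compound 4 (0.08 log units; within the scatter). For compound 4 the estimated value is 300 nM, with an expected range from 100 nM to 900 nM.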

Compound 4, half-maximal inhibitory concentration: 640 nM
Beside the measured number, compound 4's estimate is 2.1-fold (0.33 log units) below it; low and high end bracket the measured number.
By their numbers in this assay, from the lowest: compound 3; then compound 4; then compounds 1 and 2 (each within the scatter of the next).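

In this assay, the carbonyl carbon bound to the amide-type nitrogen proves sensitive to substitution: isopropoxy in place of tert-butyl gives a 2.6-fold higher number from compound 3 to compound 4 (0.41 log units; beyond the scatter), a modest step beyond the scatter. Among these compounds, the earlier step, a 1.1-fold higher number from compound 1 to compound 2 (0.04 log units; within the scatter), lay within the scatter and at a saturated chain carbon, so this is the first clear shift. Both groups have 4 heavy atoms, and no available data explain the shift.

Open, from the compounds shown here alone, is whether a methylamino group or a cyclopropyl ring on this carbonyl carbon would fall nearer compound 3 or compound 4. Also open, going by these compounds, is whether the step holds with a different group on the shared core.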